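Spiro series: chloro to isopropoxy on the pendant aryl

A few compounds are considered here, and "the series" means these few. Any claim that something is new, unique, unknown or untested is made for them only; others in the source may bear on it.

Measured so far:
compound 1 `CN1CC(c2ccc(Cl)cc2)[C@@]2(NC(=S)N(c3ccc(F)c(Cl)c3)C2=O)[C@@]12C(=O)Nc1ccc(Br)cc12` — 12100 nM
compound 2 `CC(C)Oc1ccc(C2CN(C)[C@]3(C(=O)Nc4ccc(Br)cc43)[C@]23NC(=S)N(c2ccc(F)c(Cl)c2)C3=O)cc1` — "not active" (no number reported)
compound 3 `CN1CC(c2ccc(Cl)cc2)[C@@]2(NC(=S)N(c3ccc(F)c(Cl)c3)C2=O)[C@@]12C(=O)Nc1ccccc12` — 7650 nM

Three compounds on a shared core have been run in a functional assay on SiHa cells (Homo sapiens) for cytotoxicity, read by MTT assay, with a stated time of 48 h; a higher number here means a weaker inhibitor, a lower number a stronger inhibitor. Compound 1 gives 12100 nM and compound 3, which carries hydrogen in place of bromo on an aromatic carbon, gives 7650 nM; the step of a 1.6-fold lower number from compound 1 to compound 3 (0.20 log units; within the scatter) is within the scatter, so the two cannot be ordered. Compound 2 is reported as "not active" (no number reported) with no number.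

Compound 3 has the lowest of the two numbers shown, with compound 1 next to it within the scatter.

Compound 4 `CC(C)Oc1ccc(C2CN(C)[C@]3(C(=O)Nc4ccccc43)[C@]23NC(=S)N(c2ccc(F)c(Cl)c2)C3=O)cc1` is not yet measured. It differs from compound 3 by isopropoxy in place of chloro on an aromatic carbon. Within the data shown here, no step with a number covers this change directly. Among the measured compounds shown here, the only pair that shows it is compound 1 against compound 2: compound 1 gives 12100 nM, and compound 2 is recorded as "not active" (no number reported). That pair points to a weaker inhibitor after the change, though without a number its size is open.

Compound 4 is therefore expected to give a higher number than compound 3, by the step of a 5.2-fold higher number from compound 3 to compound 4 (0.72 log units; beyond the scatter). The estimate for compound 4 in this assay is 40000 nM, with a range from 12000 nM to 150000 nM, and a real chance that only a limit is reported.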

Compound 4, half-maximal inhibitory concentration: "not active" (no number reported)
The entry for compound 4 holds no number; the estimate stays without a comparison.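

In this assay, among these compounds, compound 4 is recorded as "not active" (no number reported), so no step from compound 3 to compound 4 can be read. The compounds shown leave open the size of the change from 4-chlorophenyl to 4-isopropoxyphenyl, as neither compound 2 nor compound 4 has a number. No evidence bears on this result.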